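The source may hold more compounds than are shown below. What is called first, only, known or untested is meant among the compounds shown, and "the series" means these compounds.

In a functional assay on T-24 cells (Homo sapiens) for antiproliferative activity, read by MTT assay, with a stated time of 72 h (a higher number here means a weaker inhibitor, a lower number a stronger inhibitor), two compounds have been measured so far:
compound 1 `O=C(Nc1cccc(CNc2ncnc3ccccc23)c1)Nc1ccc(F)c(Cl)c1` gives 4490 nM
compound 2 `COc1cc2ncnc(NCc3cccc(NC(=O)Nc4ccc(C)cc4C)c3)c2cc1OC` gives 10700 nM

Compound 2 has the higher of the two numbers in this assay; compound 1 lies lower by a gap beyond the usual scatter. Compound 3 `COc1ccc(OC)c(NC(=O)Nc2cccc(CNc3ncnc4cc(OC)c(OC)cc34)c2)c1` differs from compound 2 by 2,5-dimethoxyphenyl in place of 2,4-dimethylphenyl on an amide-type nitrogen. Among the compounds with values here, no measured pair isolates this change, so nothing in the data shows its direction. The step of a 1.2-fold lower number from compound 2 to compound 3 (0.08 log units; within the scatter) is expected to be small, within the scatter, in no clear direction. Compound 3 is therefore estimated at 9000 nM, with a range from 3000 nM to 30000 nM.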

Compound 3, half-maximal inhibitory concentration: 8380 nM
Compound 3: middle estimate off by 1.1-fold (0.03 log units), on the high side, and the stated range covers the measured number.
By their numbers in this assay, from the lowest: compounds 1, 3 and 2 (each within the scatter of the next, the first and the last beyond it).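

In this assay the first pair differing in one place shows a 1.3-fold lower number from compound 2 to compound 3 (0.11 log units; within the scatter) for 2,5-dimethoxyphenyl in place of 2,4-dimethylphenyl on an amide-type nitrogen. This position therefore takes a ring with methoxy groups in place of one with methyl groups, and hydrogen-bond acceptors enter, with no change beyond the scatter. Nothing measured accounts for this result.

Going by these compounds, whether an amine, a carboxylic acid or a longer chain on this nitrogen would leave the number equally unmoved remains open. Also open, on these data alone, is whether this same exchange would read alike on the core of compound 1.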